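Compound 1 to compound 4: butoxycarbonyl on the ring oxygen

The compounds below may be only part of what the source reports. "The series", "measured", "known", "first", "only" and "open" are said of these compounds alone.

Compound 1 `O=C(O)c1cc(-n2cccc2)ccc1O` is the reference point of the series. In a functional assay on the whole organism for inhibition, with Rattus norvegicus as the target, read by paw edema (a higher number here means that more compound is needed for the effect, a lower number that less compound is needed), compound 1 gives 50 mg/kg, the lowest of the two numbers shown; its nearest neighbour is compound 3 `O=C(O)c1cc(-c2ncc[nH]2)ccc1O` with 200 mg/kg, the gap being a 4.0-fold higher number from compound 1 to compound 3 (0.60 log units; beyond the scatter). Compound 2 `O=C(O)c1cc(-c2cncs2)ccc1O` reports only a limit of the assay, > 200 mg/kg (the limit of > 200 mg/kg in this assay, at which 1 of the 3 values shown sits). The step of an at least 4.0-fold higher number from compound 1 to compound 2 (0.60 log units; beyond the scatter) is therefore read only as a lower bound.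

Compound 4 `CCCCOC(=O)Oc1ccc(-n2cccc2)cc1C(=O)O` is not yet measured. It differs from compound 1 by butoxycarbonyl in place of hydrogen on an oxygen on an aromatic ring. For the measured compounds named here, both measured steps exchange the ring attached to the core for another ring and leave the oxygen untouched, so neither bears directly on this change; the series holds no pair in which that oxygen carries a substituent. With no precedent among the shown pairs, the expectation is set close to compound 1, allowing a shift in either direction that may reach a little beyond the scatter. Compound 4 is expected at 60 mg/kg in this assay, within 25 mg/kg to 150 mg/kg. The expected step is a 1.2-fold higher number from compound 1 to compound 4 (0.08 log units; within the scatter).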

Compound 4, dose for half-maximal effect: 52 mg/kg
For compound 4 the middle estimate is 1.2-fold (0.06 log units) above the measured one; the range from low to high includes it.
By their numbers in this assay, from the lowest: compounds 1 and 4 (each within the scatter of the next); then compound 3.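

In this assay, for the compounds shown here, the first change on the oxygen on an aromatic ring, butoxycarbonyl in place of hydrogen, gives a 1.0-fold higher number from compound 1 to compound 4 (0.02 log units; within the scatter). The hydrogen on that oxygen is therefore not needed to keep the number of compound 1 in this whole-animal read-out, whereas exchanging the ring attached to the core gives a 4.0-fold higher number from compound 1 to compound 3 (0.60 log units; beyond the scatter). No measurement at hand accounts for this outcome.

Still open, going by these compounds, is whether this holds for the oxygen in general or for butoxycarbonyl alone, as a methyl ether, an acetyl group, a longer chain or a chain ending in an amine or a carboxylic acid could each read differently there. Also open, on these data alone, is whether butoxycarbonyl on the same oxygen of compound 3 would leave its number equally in place.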